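The source may report more compounds than this note shows. Statements on the series, on what has been measured and on what is new or still open speak of the compounds shown alone.

Measured so far: compound 1 `CCNC(=O)c1cc(Oc2cccc(NC(=S)Nc3cccc(C(F)(F)F)c3)c2)ccn1` gives 18300 nM in a functional assay on PC-3 cells (Homo sapiens) for cytotoxicity, read by MTT assay, with a stated time of 48 h; a lower number here means a stronger inhibitor, a higher number a weaker inhibitor; compound 2 `O=C(NC1CC1)c1cc(Oc2cccc(NC(=S)Nc3cccc(C(F)(F)F)c3)c2)ccn1` gives 22100 nM.

Compound 2 holds the higher of the two numbers, yet its gap to compound 1, a 1.2-fold higher number from compound 1 to compound 2 (0.08 log units; within the scatter), lies within the scatter. Compound 3 `O=C(NCc1ccccc1)c1cc(Oc2cccc(NC(=S)Nc3cccc(C(F)(F)F)c3)c2)ccn1` differs from compound 2 by benzyl in place of cyclopropyl on an amide-type nitrogen. Among the measured compounds shown here, the only step that bears on this change is a 1.2-fold higher number from compound 1 to compound 2 (0.08 log units; within the scatter), where a change on the same amide-type nitrogen left the number essentially unchanged. No step larger than the scatter is therefore expected in this assay, and compound 3 is estimated at 18000 nM, with a range from 6000 nM to 50000 nM, a step of a 1.2-fold lower number from compound 2 to compound 3 (0.09 log units; within the scatter).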

Compound 3, half-maximal inhibitory concentration: 11000 nM
Estimate against measurement, compound 3: 1.6-fold (0.21 log units) above; low and high end bracket the measured number.
By their numbers in this assay, from the lowest: compounds 3, 1 and 2 (each within the scatter of the next).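

In this assay, benzyl brings a six-membered aromatic ring onto the amide-type nitrogen, yet a 2.0-fold lower number from compound 2 to compound 3 (0.30 log units; within the scatter) and a 1.7-fold lower number from compound 1 to compound 3 (0.22 log units; within the scatter) both lie within the scatter. Ethyl, cyclopropyl and benzyl at this position are therefore not told apart by this assay. No evidence at hand gives a cause for these numbers.

From the compounds shown here alone, whether any group on this nitrogen can produce a step beyond the scatter remains open. A longer chain ending in an amine or a carboxylic acid has no counterpart among these compounds.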